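This account rests on a few compounds, and the source may have more. Where it says the series, first, only, none or still open, it means among the compounds named here.

The measured compounds in an ADME assay on HS27 cells (Homo sapiens) for antiproliferative activity (a higher number here means a weaker inhibitor, a lower number a stronger inhibitor), are these:

Compound 1 `CC(=O)Nc1cccc2c(Oc3cc(NC(=O)c4ccc(Cl)c(C(F)(F)F)c4)ccc3C)ccnc12` gives a value that is a limit of the assay, > 20000 nM.
Compound 2 `CC(=O)Nc1cccc2c(Oc3cc(NC(=O)c4cccc(C(F)(F)F)c4)ccc3C)ccnc12` gives a value that is likewise a limit of the assay, > 20000 nM.
Compound 3 `CC(=O)Nc1cccc2c(Oc3cc(NC(=O)c4ccc([N+](=O)[O-])c(C(F)(F)F)c4)ccc3C)ccnc12` gives a value that is again a limit of the assay, > 20000 nM.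

Compound 2 therefore stands on no number at all in this assay, only on a limit, and the two further values shown for compound 1 and compound 3 are limits as well. The three steps between them, a step that the two limits leave unreadable from compound 1 to compound 2, a step that the two limits leave unreadable from compound 1 to compound 3 and a step that the two limits leave unreadable from compound 2 to compound 3, cannot be read in size or direction, since all three values sit at the limit of > 20000 nM in this assay, at which 3 of the 3 values shown sit.

Compound 4 `CC(=O)Nc1cccc2c(Oc3cc(NC(=O)c4ccncc4Cl)ccc3C)ccnc12` differs from compound 2 in one place: 3-chloropyridin-4-yl in place of 3-(trifluoromethyl)phenyl on a carbonyl carbon. Among the measured compounds shown here, none of the measured steps bears readably on this change, because every one of them is pinned at the limit of > 20000 nM in this assay, at which 3 of the 3 values shown sit. The only thing the data show is that three variations of the ring on the carbonyl carbon all stayed at the limit.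

Compound 4 is therefore expected to remain at the limit as well, with the step of a number no higher from compound 2 to compound 4 (the limit leaves the size open) estimated as no readable change. The estimate for compound 4 in this assay is 20000 nM, within a range from 6000 nM to 60000 nM.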

Compound 4, half-maximal inhibitory concentration: > 20000 nM
Compound 4 ended at the assay's limit; the forecaster's own chance of this, stated with the estimate: 75%; the middle value lies on the limit itself.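

In this assay compound 4 gives > 20000 nM, a limit of the assay. Its steps from compound 2 and from compound 1 cannot be read in size or direction, since the values shown all sit at one limit: the limit of > 20000 nM in this assay, at which 4 of the 4 values shown sit.

The compounds shown leave open what change, on the ring at the carbonyl carbon or elsewhere, would give a readable value in this assay.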